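The source may hold more compounds than are shown below. What is called first, only, known or untested is meant among the compounds shown, and "the series" means these compounds.

Of the compounds shown here, two have so far been tested in a functional assay on the whole organism with Mus musculus as the target; a lower number here means that less compound is needed, a higher number that more compound is needed for the effect. Compound 1 (`NCC(=O)NCc1nncn1-c1ccc(Cl)cc1C(=O)c1ccccc1`) gives 1.66 mg/kg, and compound 2 (`Cc1nnc(CNC(=O)CN)n1-c1ccc(Cl)cc1C(=O)c1ccccc1F`) gives 0.16 mg/kg. Compound 2 therefore holds the lower of the two numbers, and its gap to compound 1 lies beyond the usual scatter.

Compound 3 (`Cc1nnc(CNC(=O)CN)n1-c1ccc(Cl)cc1C(=O)c1ccccc1`) has not yet been measured. It differs from compound 2 in one place: hydrogen in place of fluoro on an aromatic carbon. Hydrogen takes the place of fluoro on an aromatic carbon, ortho to a large group, so that 2-fluorophenyl becomes phenyl. Within the data shown here, no pair of measured compounds shows this change on its own, which leaves its size open. A move to a higher number in this assay seems more likely than a move to a lower one, since compound 2 at 0.16 mg/kg stands at the low end of the numbers seen so far. The expected result is a 3.1-fold higher number from compound 2 to compound 3 (0.49 log units; beyond the scatter), a moderate loss that may only just clear the scatter. Compound 3 is expected at 0.5 mg/kg, with an estimated range of 0.16 mg/kg to 1.6 mg/kg.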

Compound 3, dose for half-maximal effect: 0.94 mg/kg
Beside the measured number, compound 3's estimate is 1.9-fold (0.27 log units) below it, within the range that was stated.
By their numbers in this assay, from the lowest: compound 2; then compounds 3 and 1 (each within the scatter of the next).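

In this assay, the 2-fluorophenyl group of compound 2 proves to matter: the change to phenyl gives a 5.9-fold higher number from compound 2 to compound 3 (0.77 log units; beyond the scatter) and so marks this position as one where a single fluoro on an aromatic carbon ortho to a large group has a measurable effect in the whole animal. The other single change now readable, a 1.8-fold lower number from compound 1 to compound 3 (0.25 log units; within the scatter) for methyl in place of hydrogen on an aromatic carbon, cannot be told apart from the scatter, so of these two steps only the fluoro step stands out. No measurement at hand bears on the reason for the fluoro step.

The compounds shown leave open whether chloro, methyl or methoxy at this same position would behave as fluoro does, and whether fluoro would matter equally at another place on that ring. They also leave open whether the fluoro step keeps its size in a compound carrying hydrogen instead of the methyl, and how a longer chain in place of the aminoacetamide side chain would read in this test.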